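Amide tail variation on a shared core

The source may report more compounds than this note shows. Statements on the series, on what has been measured and on what is new or still open speak of the compounds shown alone.

Three compounds sharing one core have been run in an assay on isolated protein for inhibition of thyroid hormone receptor beta (Homo sapiens), read by fluorescence polarization; a higher number here means a weaker inhibitor, a lower number a stronger inhibitor. Compound 1 `Cc1ccc(N2CCN(C(=O)C3CCN(C(=O)c4ccc(S(C)(=O)=O)c([N+](=O)[O-])c4)CC3)CC2)cc1` carries the longest tail of the set. In this assay compound 1 reaches only the limit of the method, > 60000 nM. Compound 3 `CC(C)N(C(=O)C1CCN(C(=O)c2ccc(S(C)(=O)=O)c([N+](=O)[O-])c2)CC1)C(C)C` ends in a diisopropylamide on a ring linker. In this assay compound 3 likewise stops at the limit, > 60000 nM. Compound 2 `CC(C)N(C(=O)CCNC(=O)c1ccc(S(C)(=O)=O)c([N+](=O)[O-])c1)C(C)C` keeps the diisopropylamide but on an open-chain linker. In this assay compound 2 also gives no number but a limit, > 60000 nM. Within the data shown here, compound 2 therefore stands nowhere distinct from the others: every value so far sits at the limit of > 60000 nM in this assay, at which 3 of the 3 values shown sit, and no step between measured compounds can be sized.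

Compound 4 `CS(=O)(=O)c1ccc(C(=O)NCCC(=O)N2CCCCC2)cc1[N+](=O)[O-]` is the next member. piperidin-1-yl in place of diisopropylamino on a carbonyl carbon The change is confined to the terminal amide; the core and the open-chain linker are unchanged. Since all values rest at the limit of > 60000 nM in this assay, at which 3 of the 3 values shown sit, no direction can be read from the data, and the expectation is no step beyond the scatter. The estimated step is a number no higher from compound 2 to compound 4 (the limit leaves the size open). Compound 4 is expected to remain at the limit, estimated at 60000 nM, within 20000 nM to 200000 nM.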

Compound 4, half-maximal inhibitory concentration: > 60000 nM
Compound 4 ended at the assay's limit; the forecaster's own chance of this, stated with the estimate: 85%; the middle value lies on the limit itself.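

In this assay compound 4 gives > 60000 nM as a limit of the assay, not a number. With compound 2 also resting on a limit, no step can be read between compound 2 and compound 4. The compounds shown leave open whether any amide tail on the shared core gives a measurable value in this assay at all.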